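Amide variation on a dimethoxy bicyclic series

A few compounds are considered here, and "the series" means these few. Any claim that something is new, unique, unknown or untested is made for them only; others in the source may bear on it.

For the measured compounds named here, compound 3 `COc1cc2c(cc1OC)C(CC(=O)N1CCNCC1)CC2` stands highest of the three numbers so far in a functional assay on the whole organism (strain Wistar) for inhibition, with Rattus norvegicus as the target, read by paw edema, with stated times of 60 min and 2 h, at a dose of 100 mg/kg by the oral route; on this read-out higher numbers stand for more inhibition at the one dose given (going by the name of the read-out) and lower numbers for less inhibition: compound 3 gives 44%. Compound 1 `CNC(=O)CC1CCc2cc(OC)c(OC)cc21` gives 30% and compound 2 `COc1cc2c(cc1OC)C(CC(=O)NCc1ccccc1)CC2` gives 24%; the steps of a number 14 percentage points higher from compound 1 to compound 3 (beyond the scatter) and a number 20 percentage points higher from compound 2 to compound 3 (beyond the scatter) set compound 3 apart. Compound 4 `COc1cc2c(cc1OC)C(CC(=O)NCCO)CC2` is not yet measured; it differs from compound 3 by (2-hydroxyethyl)amino in place of piperazin-1-yl on a carbonyl carbon. The two steps that bear on this run the other way: each replaced an acyclic amine on the carbonyl carbon by piperazin-1-yl and gained a modest amount. Removing piperazin-1-yl again is therefore expected to cost a step of similar size, back toward the level of compound 1. Compound 4 is expected to give 32%, with a range of 18% to 46%, a step of a number 12 percentage points lower from compound 3 to compound 4 (beyond the scatter) in this assay.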

Compound 4, a percentage reported as inhibition, in the whole organism at one dose (the size of the read-out at that dose, not a potency): 0%
Estimate against measurement, compound 4: 32 percentage points above; the whole stated range lies above it.
By their numbers in this assay, from the lowest: compound 4; then compounds 2 and 1 (each within the scatter of the next); then compound 3.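

In this assay the change on the carbonyl carbon to (2-hydroxyethyl)amino gives a number 44 percentage points lower from compound 3 to compound 4 (beyond the scatter) and so shows that amides without a ring at this position do not share one level. On the saturated chain carbon bound to an amide-type nitrogen, hydroxymethyl differs from both other substituents, with a number 30 percentage points lower from compound 1 to compound 4 (beyond the scatter) and with a number 24 percentage points lower from compound 2 to compound 4 (beyond the scatter) while hydrogen and phenyl there stay within the scatter of each other. Nothing at hand accounts for this loss.

Still open, on these data alone, is whether the loss follows the hydroxyl of compound 4 or the absence of the piperazin-1-yl ring. Morpholin-4-yl or 2-methoxyethylamino on the carbonyl carbon would separate these two readings.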